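The source may hold more compounds than are shown below. What is called first, only, known or untested is meant among the compounds shown, and "the series" means these compounds.

Among the measured compounds shown here, in an assay on CHO cells for displacement of a labelled ligand from Substance-P receptor (Homo sapiens), in the presence of a further agent that is not named here (on this read-out higher numbers stand for weaker inhibition and lower numbers for stronger inhibition), compound 1 `C[C@@H](O[C@H]1CN2C(=O)C=C(c3cc[n+]([O-])cc3)CC2[C@@H]1c1ccc(F)cc1)c1cc(C(F)(F)F)cc(C(F)(F)F)c1` gives 2.1 nM, the lowest of the three numbers measured so far. Compound 2 `C[C@@H](O[C@H]1CN2C(=O)C=C(c3ccc[n+]([O-])c3)CC2[C@@H]1c1ccc(F)cc1)c1cc(C(F)(F)F)cc(C(F)(F)F)c1` gives 2.3 nM, and compound 3 `C[C@@H](O[C@H]1CN2C(=O)C=C(C3=CCC(O)CC3)CC2[C@@H]1c1ccc(F)cc1)c1cc(C(F)(F)F)cc(C(F)(F)F)c1` gives 13 nM. The step of a 1.1-fold higher number from compound 1 to compound 2 (0.04 log units; within the scatter) lies within the scatter, whereas the steps of a 6.2-fold higher number from compound 1 to compound 3 (0.79 log units; beyond the scatter) and a 5.7-fold higher number from compound 2 to compound 3 (0.75 log units; beyond the scatter) go beyond it. Compound 4 `C[C@@H](O[C@H]1CN2C(=O)C=C(C3=CCOCC3)CC2[C@@H]1c1ccc(F)cc1)c1cc(C(F)(F)F)cc(C(F)(F)F)c1` differs from compound 1 as follows: a group of 6 heavy atoms (5 carbon, 1 oxygen; one six-membered non-aromatic ring with 1 hetero atom) in place of a group of 7 heavy atoms (5 carbon, 1 nitrogen, 1 oxygen; one six-membered aromatic ring with 1 hetero atom), on a double-bonded ring carbon. For the measured compounds named here, the only step that bears on this change is the one in which a six-membered non-aromatic ring replaced the aromatic ring with one hetero atom, and a weakening of similar size is expected for compound 4 because of a 6.2-fold higher number from compound 1 to compound 3 (0.79 log units; beyond the scatter). Compound 4 is therefore expected to show a 4.8-fold higher number from compound 1 to compound 4 (0.68 log units; beyond the scatter). The estimated value for compound 4 is 10 nM, within a range from 3.5 nM to 30 nM.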

Compound 4, half-maximal inhibitory concentration: 9.6 nM
Beside the measured number, compound 4's estimate is 1.0-fold (0.02 log units) above it; the range from low to high includes it.
By their numbers in this assay, from the lowest: compounds 1 and 2 (each within the scatter of the next); then compounds 4 and 3 (each within the scatter of the next).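

In this assay, replacing the aromatic ring with the non-aromatic ring containing one hetero atom gives a 4.6-fold higher number from compound 1 to compound 4 (0.66 log units; beyond the scatter) and a 4.2-fold higher number from compound 2 to compound 4 (0.62 log units; beyond the scatter). Exchanging the carbon-only ring for that ring gives a 1.4-fold lower number from compound 3 to compound 4 (0.13 log units; within the scatter), so at this double-bonded ring carbon the two non-aromatic rings are not told apart, and both give higher numbers than the two aromatic rings. Nothing available explains this difference. From the compounds shown here alone, whether a piperidine ring or an unsubstituted phenyl ring here would give numbers like those of compound 1 remains open.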